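The source may report more compounds than this note shows. Statements on the series, on what has been measured and on what is new or still open speak of the compounds shown alone.

Measured so far: compound 1 `CN1CCN(c2ccccc2C(=O)/C=C/c2ccc(/C=C/C(=O)NO)cc2)CC1` gives 1600 nM; compound 2 `O=C(/C=C/c1ccc(/C=C/C(=O)c2ccccc2)cc1)NO` gives 2280 nM; compound 3 `O=C(/C=C/c1cccc(/C=C/C(=O)c2ccccc2)n1)NO` gives 510 nM.

These three were tested in a functional assay on K562 cells (Homo sapiens) for antiproliferative activity, read by MTT assay, with a stated time of 72 h; a higher number here means a weaker inhibitor, a lower number a stronger inhibitor. Compound 3 has the lowest number of the three; compound 1 comes nearest, compound 2 furthest, and both gaps lie beyond the scatter. How the core of compound 3 differs from that of compound 2 is not broken down here.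

Compound 4 `CN1CCN(c2ccccc2C(=O)/C=C/c2cccc(/C=C/C(=O)NO)n2)CC1` has not yet been measured. Its change from compound 3, (4-methylpiperazin-1-yl in place of hydrogen on an aromatic carbon), is the same change as that from compound 2 to compound 1, (4-methylpiperazin-1-yl in place of hydrogen on an aromatic carbon), which occurs twice among these compounds. In this assay that step was a 1.4-fold lower number from compound 2 to compound 1 (0.15 log units; within the scatter). Compound 4 is expected to follow compound 3 with a step of about a 1.3-fold lower number from compound 3 to compound 4 (0.11 log units; within the scatter), because the earlier step of a 1.4-fold lower number from compound 2 to compound 1 (0.15 log units; within the scatter) was small. Compound 4 is estimated at 400 nM, between 180 nM and 900 nM.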

Compound 4, half-maximal inhibitory concentration: 700 nM
The estimate for compound 4 lay 1.8-fold (0.24 log units) below the measured number; measured number inside the range.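

In this assay, the 4-methylpiperazin-1-yl group in place of hydrogen brought a 1.4-fold higher number from compound 3 to compound 4 (0.14 log units; within the scatter). Set beside the earlier step, the change gave no difference between the two cores that stands out from the scatter: the same change on two cores in this assay, a 1.4-fold lower number (0.15 log units; within the scatter) from compound 2 to compound 1 and a 1.4-fold higher number (0.14 log units; within the scatter) from compound 3 to compound 4, 2.0-fold (0.29 log units) apart, within the scatter of two such steps. Among the compounds shown here, this shows that the change stayed small on both cores in this assay, but with only two pairs, each within the scatter, it fixes no direction for the change, gives no reason for its size and says nothing about other cores.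

The compounds shown leave open whether a morpholine or a dimethylamino group in place of the same hydrogen would give a similarly small step. They also leave open whether a longer chain carrying such an amine would do so.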